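The source may report more compounds than this note shows. Statements on the series, on what has been measured and on what is new or still open speak of the compounds shown alone.

Compound 1 `CNC(=O)c1cc(Oc2ccc3sc(Nc4cccc(C(C)(C)C)c4)nc3c2)ccn1` gives 10 10^-6 cm/s in an ADME assay on Caco-2 cells (Homo sapiens) for permeability, in the apical to basolateral direction; on this read-out lower numbers stand for lower permeability and higher numbers for higher permeability. Compound 2 `CNC(=O)c1cc(Oc2ccc3oc(Nc4ccccc4Cl)nc3c2)ccn1` gives 10 10^-6 cm/s. Compound 3 `CNC(=O)c1cc(Oc2ccc3sc(Nc4ccc(C)cc4)nc3c2)ccn1` gives 10 10^-6 cm/s.

Compound 3 thus stands level with compounds 1 and 2 in this assay, within the scatter of both. Compound 4 `CNC(=O)c1cc(Oc2ccc3sc(Nc4ccc(OC(F)(F)F)cc4)nc3c2)ccn1` differs from compound 3 by trifluoromethoxy in place of methyl on an aromatic carbon. For the measured compounds named here, one measured step bears on this change: the exchange of one group on the same aromatic ring in no change at the digits printed from compound 1 to compound 3 (within the scatter), which left this assay unchanged within the scatter. Another exchange of the group on that ring is therefore expected to give no step beyond the scatter in this assay, that is no change at the digits printed from compound 3 to compound 4 (within the scatter). Compound 4 is expected to give 10 10^-6 cm/s, with a range from 6 10^-6 cm/s to 17 10^-6 cm/s.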

Compound 4, apparent permeability: 10 10^-6 cm/s
Compound 4: the middle estimate sits on the measured number at the digits printed; measured number inside the range.
By their numbers in this assay, from the lowest: compounds 1, 2, 3 and 4 (each within the scatter of the next).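

With the position on the ring held fixed, trifluoromethoxy in place of methyl, on an aromatic carbon para to a large group, gives no change at the digits printed from compound 3 to compound 4 (within the scatter) in this assay. Unlike the earlier step, this one compares two groups at the same place, and the entering group brings more heavy atoms and a hydrogen-bond acceptor without moving the read-out beyond the scatter. No evidence on the reason for this is available. Going by these compounds, whether an amine or a carboxylic acid at this place would also leave the read-out level remains open.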